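Replacing the thiazole arm of compound 1 with an oxadiazole

The source may report more compounds than this note shows. Statements on the series, on what has been measured and on what is new or still open speak of the compounds shown alone.

Measured compounds:
compound 1 `Cc1nc(-c2ccccc2)sc1CN1C(=O)N(C)c2ccc(-c3c(C)noc3C)cc2C1c1ccccc1` — 35.1%
compound 2 `Cc1nc(-c2ccc(F)cc2)sc1CN1C(=O)N(C)c2ccc(-c3c(C)noc3C)cc2C1c1ccccc1` — 33.4%

In a functional assay on MCF7 cells (Homo sapiens) for inhibition, read by MTT assay, with a stated time of 48 h, tested at 2 uM (a higher number here means more inhibition at the concentration tested (going by the name of the read-out), a lower number less inhibition), compound 1 gives 35.1%, the higher of the two numbers, and compound 2 gives 33.4%; the step of a number 1.7 percentage points lower from compound 1 to compound 2 (within the scatter) lies within the scatter, so the two cannot be ordered. Compound 3 `Cc1noc(C)c1-c1ccc2c(c1)C(c1ccccc1)N(Cc1nnc(-c3ccc(F)cc3)o1)C(=O)N2C` differs from compound 1 by 5-(4-fluorophenyl)-1,3,4-oxadiazol-2-yl in place of 4-methyl-2-phenyl-1,3-thiazol-5-yl on a saturated chain carbon bound to an amide-type nitrogen in a ring. For the measured compounds named here, the only measured step, a number 1.7 percentage points lower from compound 1 to compound 2 (within the scatter), concerns a fluoro in place of hydrogen on an aromatic carbon and does not touch the ring that is exchanged here, so no measured step bears directly on the change. The exchange of the whole arm is large, and the data give no guide to its direction; the expected step of a number 5.1 percentage points lower from compound 1 to compound 3 (within the scatter) is therefore set near zero with a wide range. Compound 3 is thus estimated at 30%, between 8% and 55%.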

Compound 3, a percentage reported as inhibition, at one concentration (the size of the read-out at that concentration, not a potency): 26.7%
Compound 3: the middle estimate sits 3.3 percentage points above what was measured; measured number inside the range.
By their numbers in this assay, from the lowest: compounds 3, 2 and 1 (each within the scatter of the next).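

In this assay, the whole arm on the saturated chain carbon bound to an amide-type nitrogen in a ring was exchanged, and this gives a number 8.4 percentage points lower from compound 1 to compound 3 (within the scatter). Compounds 1 and 2 had tested only a fluoro in place of hydrogen on an aromatic carbon, whereas this step shows that a much larger change at this place, 5-(4-fluorophenyl)-1,3,4-oxadiazol-2-yl in place of 4-methyl-2-phenyl-1,3-thiazol-5-yl, also leaves the read-out within the scatter. No supporting measurement is available to explain this result.

As far as these compounds go, it remains open whether an arm carrying an amine or a carboxylic acid, or a longer chain at this place, would shift the number beyond the scatter. From the compounds shown here alone, since each compound is read at one concentration, their potencies also remain open.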